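This account rests on a few compounds, and the source may have more. Where it says the series, first, only, none or still open, it means among the compounds named here.

Compound 1 `O=C(NNC(=S)Nc1csc(-c2ccccc2)c1)c1ccc(O)cc1` sits at the start of the series, and in a functional assay on B16-F10 cells (Mus musculus) for inhibition, read by colorimetric assay and MTT assay, with a stated time of 72 h (a lower number here means a stronger inhibitor, a higher number a weaker inhibitor), compound 1 gives 40000 nM. Compound 2 `Cc1ccc(-c2cc(NC(=S)NNC(=O)c3ccc(O)cc3)cs2)cc1` carries methyl in place of hydrogen on an aromatic carbon and in this assay compound 2 gives 48000 nM, a step of a 1.2-fold higher number from compound 1 to compound 2 (0.08 log units; within the scatter). Compound 3 `COc1cc(OC)cc(C(=O)NNC(=S)Nc2csc(-c3ccccc3)c2)c1` has another core; the difference between the two cores is not broken down here. In this assay compound 3 gives 30000 nM, a number within the scatter of those of compound 1 and compound 2. Compound 4 `COc1cc(OC)cc(C(=O)NNC(=S)Nc2csc(-c3ccc(C)cc3)c2)c1` is not yet measured; it differs from compound 3 by methyl in place of hydrogen on an aromatic carbon, the same change as that between compound 1 and compound 2. The expected step is a 1.2-fold higher number from compound 3 to compound 4 (0.08 log units; within the scatter), because the earlier step was a 1.2-fold higher number from compound 1 to compound 2 (0.08 log units; within the scatter). Compound 4 is therefore estimated at 36000 nM, likely between 20000 nM and 65000 nM.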

Compound 4, half-maximal inhibitory concentration: 13000 nM
For compound 4 the middle estimate is 2.8-fold (0.44 log units) above the measured one; the measured number lies below the stated range.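

In this assay, methyl in place of hydrogen on the aromatic ring gives a 2.3-fold lower number from compound 3 to compound 4 (0.36 log units; beyond the scatter), a modest step. The same change therefore does not carry over unchanged from one core to the other: the same change on two cores in this assay, a 1.2-fold higher number (0.08 log units; within the scatter) from compound 1 to compound 2 and a 2.3-fold lower number (0.36 log units; beyond the scatter) from compound 3 to compound 4, 2.8-fold (0.44 log units) apart, beyond the scatter of two such steps This shows that the step measured on the core of compound 1 cannot stand in for the step on the core of compound 3, but it does not show why the two steps differ, and two pairs give no rule for any further core.

The compounds shown leave open what a longer chain, such as ethyl, or an amine would do at that place on either core. Going by these compounds, how the methyl step behaves on any other core also stays open.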